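Isopropylamino for piperazinyl on the shared core

A few compounds are considered here, and "the series" means these few. Any claim that something is new, unique, unknown or untested is made for them only; others in the source may bear on it.

Measured compounds:
compound 1 `FC(F)(F)c1ccc(Nc2ncnc3sc(Nc4c(Cl)cccc4Cl)nc23)cc1`: 3 nM
compound 2 `FC(F)(F)c1ccc(Nc2nc(N3CCNCC3)nc3sc(Nc4c(Cl)cccc4Cl)nc23)cc1`: > 5000 nM

Compound 1 `FC(F)(F)c1ccc(Nc2ncnc3sc(Nc4c(Cl)cccc4Cl)nc23)cc1` in a functional assay on HEK293 cells for antagonist activity at transient receptor potential cation channel subfamily V member 1 (Rattus norvegicus), read by calcium flux (on this read-out lower numbers stand for stronger inhibition and higher numbers for weaker inhibition), gives 3 nM. Compound 2 `FC(F)(F)c1ccc(Nc2nc(N3CCNCC3)nc3sc(Nc4c(Cl)cccc4Cl)nc23)cc1` gives in this assay only a limit, > 5000 nM, and this value sits at the limit of > 5000 nM in this assay, at which 1 of the 2 values shown sits, so no number is known for it. The step of an at least 1600-fold higher number from compound 1 to compound 2 (3.22 log units; beyond the scatter) is large and well beyond the scatter; of the two values shown, compound 2 is the weaker, and only its lower bound is known.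

Compound 3 `CC(C)Nc1nc(Nc2ccc(C(F)(F)F)cc2)c2nc(Nc3c(Cl)cccc3Cl)sc2n1` differs from compound 2 by isopropylamino in place of piperazin-1-yl on an aromatic carbon. Among the compounds with values here, the only measured step that bears on this change is an at least 1600-fold higher number from compound 1 to compound 2 (3.22 log units; beyond the scatter), which shows that substituting this position of the shared core with piperazin-1-yl costs a great deal relative to compound 1. Isopropylamino is a different substituent at the same place, without a ring, so how much of that loss it shares cannot be read from the data; some recovery toward compound 1 is plausible but not assured. Compound 3 is therefore expected to land around 1000 nM, within a wide range of 100 nM to 6000 nM. The estimated step of an at least 5.0-fold lower number from compound 2 to compound 3 (0.69 log units; beyond the scatter) from the limit of compound 2 is accordingly tentative.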

Compound 3, half-maximal inhibitory concentration: 9 nM
Estimate against measurement, compound 3: 110-fold (2.05 log units) above; the measured number lies below the stated range.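

In this assay, the position on an aromatic carbon between two ring nitrogen atoms proves able to carry a substituent: with isopropylamino in place of hydrogen the change is a 3.0-fold higher number from compound 1 to compound 3 (0.48 log units; beyond the scatter), a modest step, so the large loss seen with piperazin-1-yl does not follow from substitution at this place as such. Exchanging piperazin-1-yl for isopropylamino gives an at least 550-fold lower number from compound 2 to compound 3 (2.74 log units; beyond the scatter), which makes the identity of the group, and not merely the filling of the position, what separates these two compounds. Compound 2 stands only at a limit, so this large step carries a bound and no exact size: the limit of > 5000 nM in this assay, at which 1 of the 3 values shown sits.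

The exchange removes a six-membered non-aromatic ring and changes the heavy-atom and acceptor counts together, so this single pair cannot show which of these differences matters. A morpholin-4-yl group, a 4-methylpiperazin-1-yl group or an open chain such as 2-aminoethylamino at the same place would help separate the effect of the ring from that of the second ring nitrogen.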